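The source may report more compounds than this note shows. Statements on the series, on what has been measured and on what is new or still open speak of the compounds shown alone.

Measured compounds:
- compound 1 `CN1Cc2ccc(OCc3ccccc3)cc2[C@@H](O)C1`: in an ADME assay on Vero cells (Chlorocebus sabaeus) for cytotoxicity, read by sulforhodamine B assay, with a stated time of 72 h (on this read-out higher numbers stand for weaker inhibition and lower numbers for stronger inhibition), compound 1 gives > 100000 nM, a limit of the assay.
- compound 2 `CN1Cc2ccc(OCc3ccc(Br)cc3)cc2[C@@H](O)C1`: compound 2 gives 37000 nM.
- compound 3 `CN1Cc2ccc(OCc3ccc(-c4ccc(Cl)cc4)cc3)cc2[C@@H](O)C1`: compound 3 gives 21700 nM.

Compound 3 carries the lower of the two numbers reported as numbers, though the step of a 1.7-fold lower number from compound 2 to compound 3 (0.23 log units; within the scatter) is within the scatter; against compound 1 the step is an at least 4.6-fold lower number from compound 1 to compound 3 (0.66 log units; beyond the scatter). Compound 4 `CN1Cc2ccc(OCc3ccc(-c4ccc5ccccc5c4)cc3)cc2[C@@H](O)C1` differs from compound 3 by naphthalen-2-yl in place of 4-chlorophenyl on an aromatic carbon. Going by the values given here, the only measured step exchanging one substituent for another at this carbon, a 1.7-fold lower number from compound 2 to compound 3 (0.23 log units; within the scatter), was small; the bromo and 4-chlorophenyl steps from compound 1, an at least 2.7-fold lower number from compound 1 to compound 2 (0.43 log units; beyond the scatter) and an at least 4.6-fold lower number from compound 1 to compound 3 (0.66 log units; beyond the scatter), run downward from a limit. A step of a 1.4-fold lower number from compound 3 to compound 4 (0.16 log units; within the scatter) is therefore expected, at most a modest lowering, possibly within the scatter. Compound 4 is estimated at 15000 nM, range 5000 nM to 45000 nM.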

Compound 4, half-maximal inhibitory concentration: 310 nM
Beside the measured number, compound 4's estimate is 48-fold (1.68 log units) above it; measured number below the stated range.
By their numbers in this assay, from the lowest: compound 4; then compounds 3 and 2 (each within the scatter of the next). At a limit, above all of these: compound 1.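

In this assay, going by these compounds alone, this carbon proves far more sensitive than the earlier compounds suggested: exchanging one aryl group for another gives a 70-fold lower number from compound 3 to compound 4 (1.85 log units; beyond the scatter), and the same group in place of bromo gives a 120-fold lower number from compound 2 to compound 4 (2.08 log units; beyond the scatter). Naphthalen-2-yl brings two six-membered aromatic rings where 4-chlorophenyl brings one, so a single aryl exchange here can move the number widely. The step of an at least 320-fold lower number from compound 1 to compound 4 (2.50 log units; beyond the scatter) is only a bound, as compound 1 stands at a limit: the limit of > 100000 nM in this assay, at which 1 of the 4 values shown sits.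

Still open, from the compounds shown here alone, is whether the second ring or the loss of chlorine drives the change. A plain phenyl or naphthalen-1-yl at this carbon would separate these.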